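Series notes: fluorophenyl for methylphenyl on the shared core

The compounds below may be only part of what the source reports. "The series", "measured", "known", "first", "only" and "open" are said of these compounds alone.

Among the measured compounds shown here, compound 1 `Cc1ccc(-c2cnc(NC(=O)c3ccc(F)cc3)n2C)cc1` is the only member of the series with a numerical reading in a toxicity assay on THP-1 cells (Homo sapiens) for inhibition; on this read-out lower numbers stand for higher toxicity in this test and higher numbers for lower toxicity in this test: in this assay compound 1 gives 60000 nM. The second measured member, compound 2 `Cn1c(-c2ccccc2)cnc1NC(=O)c1cc(-c2ccccn2)[nH]n1`, returns only a limit of the assay rather than a number; in this assay compound 2 gives > 50000 nM. Since one of the two readings is a limit, compound 1 stands alone as the sole defined point, and nothing can be said about the size of any step between the two measured compounds (the limit of > 50000 nM in this assay, at which 1 of the 2 values shown sits).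

Compound 3 `Cn1c(-c2cccc(F)c2)cnc1NC(=O)c1ccc(F)cc1` has not yet been measured in this assay. Relative to compound 1 the change is 3-fluorophenyl in place of 4-methylphenyl on an aromatic carbon. The aryl group that leaves and the one that enters carry the same heavy-atom count and neither adds a donor, an acceptor or a charge.

For the measured compounds named here, with no measured step available and with compound 1 already far from the toxic end at 60000 nM, no shift beyond the usual scatter of this assay is expected for the step from compound 1 to compound 3, which is estimated at no change at the digits printed from compound 1 to compound 3 (within the scatter). Compound 3 is expected to give about 60000 nM in this assay, with a range of 30000 nM to 120000 nM; a limit reading rather than a number would not be surprising.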

Compound 3, half-maximal cytotoxic concentration: 58000 nM
Compound 3: the middle estimate sits 1.0-fold (0.01 log units) above what was measured, and the stated range covers the measured number.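

In this assay the series now has its first readable step, a 1.0-fold lower number from compound 1 to compound 3 (0.01 log units; within the scatter), where compound 1 alone had offered a single defined point. At this aromatic carbon of the shared core, next to the ring atom that bears a methyl group, 3-fluorophenyl in place of 4-methylphenyl therefore leaves the read-out within the scatter, so this exchange between two aryl groups of equal heavy-atom count, neither with a donor or acceptor, gives no sign of a change in toxicity in this test. The step alters both the substituent and where it sits on the phenyl ring, so this single pair cannot separate the two changes and shows only that their combined result stays within the scatter.

Compound 2 gives a limit of the assay rather than a number, so steps involving it cannot be read: the limit of > 50000 nM in this assay, at which 1 of the 3 values shown sits. Going by these compounds, it remains open whether a carboxylic acid or an aminomethyl group on the phenyl ring at this position, or a pyridine in place of that ring, would give lower numbers than those of compound 1 and compound 3.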